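Swapping an ethyl ether for a ketone-bearing ring

The compounds below may be only part of what the source reports. "The series", "measured", "known", "first", "only" and "open" are said of these compounds alone.

Three compounds built on a shared core, each carrying an aryl sulfonamide, have been measured in an assay for inhibition of serine/threonine-protein kinase Sgk1 (Homo sapiens), with stated times of 30 min and 60 min, in the presence of a further agent that is not named here; a lower number here means a stronger inhibitor, a higher number a weaker inhibitor. Compound 1 `CN1CCC(CNC(=O)c2cc(-c3ccc(NS(=O)(=O)c4cccc(Cl)c4Cl)cc3)nc3[nH]ncc23)C1` gives 14 nM in this assay. Among the measured compounds shown here, the only single-point change measured so far is an at least 14-fold lower number from compound 1 to compound 2 (1.14 log units; beyond the scatter), and its size rests on (the limit of < 1 nM in this assay, at which 1 of the 3 values shown sits). In this assay compound 2 `CCN1CCC(CNC(=O)c2cc(-c3ccc(NS(=O)(=O)c4cccc(Cl)c4Cl)cc3)nc3[nH]ncc23)C1` gives < 1 nM, which is a limit of the assay rather than a number. Compound 3 `CCOc1nc(-c2ccc(NS(=O)(=O)c3cc(Cl)ccc3F)cc2)nc2[nH]nc(C)c12` gives 23 nM in this assay; it sits alongside compound 1, the two numbers within the usual scatter of each other.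

Compound 4 `Cc1n[nH]c2nc(-c3ccc(NS(=O)(=O)c4cc(Cl)ccc4F)cc3)nc(OC3CCC(=O)CC3)c12` differs from compound 3 in one place: 4-oxocyclohexyl in place of ethyl on an oxygen on an aromatic ring. For the measured compounds named here, none of the measured steps speaks to this change. Going by the values given here, the one step measured concerns a methyl on an amine nitrogen in a ring, whereas here an ethyl on an aromatic oxygen is exchanged for a larger ring bearing a carbonyl, so there is no measured guide to lean on. The expectation is therefore cautious: a 1.1-fold higher number from compound 3 to compound 4 (0.04 log units; within the scatter) is estimated to stay within the scatter, with wide uncertainty. Compound 4 is expected to give about 25 nM in this assay, with a plausible range from 6 nM to 100 nM.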

Compound 4, half-maximal inhibitory concentration: 5 nM
Beside the measured number, compound 4's estimate is 5.0-fold (0.70 log units) above it; measured number outside the range, below it.
By their numbers in this assay, from the lowest: compound 4; then compounds 1 and 3 (each within the scatter of the next). At a limit, below all of these: compound 2.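

In this assay, among the compounds shown here, putting 4-oxocyclohexyl in place of ethyl on the oxygen on an aromatic ring gives a 4.6-fold lower number from compound 3 to compound 4 (0.66 log units; beyond the scatter), the first measured change at this position. It shows that this position tolerates a much larger group, with 7 heavy atoms entering where 2 leave, and that inhibition becomes stronger rather than being lost. The step adds a six-membered ring of carbon only and a carbonyl together, and no measurement shown gives a reason for the lower number.

The compounds shown leave open whether the ring, the carbonyl or both account for the step, a question that plain cyclohexyl, or the same ring with a hydroxyl or an amine in place of the carbonyl, would help to separate. Going by these compounds, it also remains open whether a ring of another size, or a longer chain on the same oxygen, would give a similar number, and whether the step would keep its size with a different aryl sulfonamide.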